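This account rests on a few compounds, and the source may have more. Where it says the series, first, only, none or still open, it means among the compounds named here.

Measured in a functional assay on PC-3 cells (Homo sapiens) for inhibition, read by sulforhodamine B assay, with a stated time of 48 h, tested at 50 uM; a higher number here means more inhibition of growth at the concentration tested, a lower number less inhibition of growth:
- Compound 1 `COc1cc(/C=C/C(=O)/C=C/c2ccco2)ccc1OCc1cn(CCCOc2cc(=O)oc3ccccc23)nn1`: "not active" (no number reported)
- Compound 2 `COc1ccc(/C=C/C(=O)/C=C/c2ccc(OCc3cn(CCCOc4cc(=O)oc5ccccc45)nn3)c(OC)c2)cc1OC`: 9%
- Compound 3 `COc1cc(/C=C/C(=O)/C=C/c2ccccc2)ccc1OCc1cn(CCCOc2cc(=O)oc3ccccc23)nn1`: "not active" (no number reported)

Going by the values given here, only one of these three compounds has a number in this assay. Compound 3 has no single value and is reported as "not active" (no number reported). Among the compounds with values here, compound 1 is the one other compound without a number, and it carries the same report of "not active" (no number reported). Within the data shown here, compound 2 is the only compound with a numerical result, at 9%. Among the measured compounds shown here, the position of compound 3 on a numerical scale is therefore not known, and no measured pair here gives the size of a single structural step.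

Compound 4 `COc1cc(/C=C/C(=O)/C=C/c2cc(OC)c(OC)c(OC)c2)ccc1OCc1cn(CCCOc2cc(=O)oc3ccccc23)nn1` has not yet been measured. It departs from its neighbour by one change, (3,4,5-trimethoxyphenyl in place of phenyl on a double-bonded chain carbon bound to a double-bonded chain carbon), which places 3,4,5-trimethoxyphenyl in place of phenyl on a double-bonded chain carbon bound to a double-bonded chain carbon.

For the measured compounds named here, with no measured step to go on, the expected change in this assay is none beyond the scatter, with compound 4 staying at the low end. This expectation rests on compound 3 at "not active" (no number reported) and on compound 2 at 9%.

The estimate for compound 4 is 8%, with an expected range of 0% to 22%.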

Compound 4, percent growth inhibition at one concentration: 12%
The estimate for compound 4 lay 4 percentage points below the measured number, within the range that was stated.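

In this assay, compound 3 is reported as "not active" (no number reported), while compound 4, which carries 3,4,5-trimethoxyphenyl in place of phenyl on a double-bonded chain carbon bound to a double-bonded chain carbon, gives 12%, so this position now has a number for a substituted ring, although it remains a low one. The distance between compound 3 and compound 4 cannot be read as a step, as compound 3 has no number. Methoxy in place of hydrogen on an aromatic carbon gives a number 3 percentage points higher from compound 2 to compound 4 (within the scatter), so in this assay that single change does not separate the two compounds.

No independent measurement is available to explain these results. From the compounds shown here alone, it remains open whether an amine or a carboxylic acid on the aromatic ring at this position, or a longer chain in place of the one that joins the triazole to the rest of the shared core, would give a result in this assay that stands clearly apart from those of compound 2 and compound 4.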